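Working notes: from compound 1 to compound 4

This account rests on a few compounds, and the source may have more. Where it says the series, first, only, none or still open, it means among the compounds named here.

Measured so far in a functional assay on MDA-MB-435 cells (Homo sapiens) for inhibition; on this read-out lower numbers stand for stronger inhibition and higher numbers for weaker inhibition:
compound 1 `O=C(/C=C/c1ccc(I)cc1)c1ccc(OCB(O)O)cc1` gives 18000 nM
compound 2 `O=C(/C=C/c1ccc(F)c(Br)c1)c1ccc(B(O)O)cc1` gives 8800 nM
compound 3 `O=C(/C=C/c1ccccc1)c1ccc[nH]1` gives 15000 nM

Compound 1 carries the highest number of the three. Its gap to compound 3 is within the scatter, so no order is drawn between those two; its gap to compound 2 lies beyond the scatter, compound 2 returning the lower number. Compound 4 `O=C(/C=C/c1ccc(I)cc1)c1ccc(O)cc1` is not yet measured. It differs from compound 1 by a hydrogen atom in place of a group of 4 heavy atoms (1 carbon, 1 boron, 2 oxygen; no ring), on an oxygen on an aromatic ring. Within the data shown here, no pair of measured compounds shows this single change, so its size is unknown from the data at hand; the shared core is kept. The expectation is a modest step toward a higher number, a 1.4-fold higher number from compound 1 to compound 4 (0.14 log units; within the scatter), possibly not beyond the scatter. Compound 4 is expected near 25000 nM, with a range from 8000 nM to 80000 nM.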

Compound 4, half-maximal inhibitory concentration: 4500 nM
For compound 4 the middle estimate is 5.6-fold (0.74 log units) above the measured one; the measured number lies below the stated range.
By their numbers in this assay, from the lowest: compounds 4, 2, 3 and 1 (each within the scatter of the next, the first and the last beyond it).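

In this assay the hydrogen atom in place of the group of 4 heavy atoms (1 carbon, 1 boron, 2 oxygen; no ring) gives a 4.0-fold lower number from compound 1 to compound 4 (0.60 log units; beyond the scatter) on an oxygen on an aromatic ring. Among these compounds, this is the first single change that can be read, and it shows that the number responds to what this oxygen carries. Nothing at hand accounts for the size of the step.

Still open, from the compounds shown here alone, is whether a small group such as methyl on this oxygen would give a number closer to that of compound 1 or compound 4. An amine in place of this oxygen is equally unresolved.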